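The source may hold more compounds than are shown below. What is called first, only, known or untested is meant among the compounds shown, and "the series" means these compounds.

Measured in a functional assay on Bel-7402 cells (Homo sapiens) for antiproliferative activity, read by MTT assay, with a stated time of 72 h; a lower number here means a stronger inhibitor, a higher number a weaker inhibitor:
- Compound 1 `C=C1C(=O)O[C@H]2[C@H]1CC/C(COC(=O)Cn1cc(F)c(=O)n(Cc3ccccc3)c1=O)=C\CC[C@@]1(C)O[C@@H]21`: 3980 nM
- Compound 2 `C=C1C(=O)O[C@H]2[C@H]1CC/C(COC(=O)CCC(=O)N1CCN(C(=O)Cn3cc(F)c(=O)n(Cc4ccccc4)c3=O)CC1)=C\CC[C@@]1(C)O[C@@H]21`: > 20000 nM (a limit of the assay, not a number)

Within the data shown here, compound 1 therefore holds the only true number so far, and the sole comparison value is a limit. Compound 3 `C=C1C(=O)O[C@H]2[C@H]1CC/C(COC(=O)Cn1cc(F)c(=O)n(Cc3ccc(F)cc3F)c1=O)=C\CC[C@@]1(C)O[C@@H]21` keeps the core of compound 1 and alters one group: 2,4-difluorophenyl in place of phenyl on a saturated chain carbon bound to an aromatic nitrogen. Put simply, it has 2,4-difluorophenyl in place of phenyl on a saturated chain carbon bound to an aromatic nitrogen, so benzyl becomes 2,4-difluorobenzyl.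

Among the measured compounds shown here, no measured pair here shows what a change of this kind does in this assay. The expectation is therefore cautious: a small shift, with no firm direction and none beyond the usual scatter of repeat measurements. The expected change is a 1.1-fold lower number from compound 1 to compound 3 (0.06 log units; within the scatter). Compound 3 is estimated at 3500 nM, with an expected range of 1300 nM to 10000 nM.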

Compound 3, half-maximal inhibitory concentration: 3670 nM
The estimate for compound 3 lay 1.0-fold (0.02 log units) below the measured number, within the range that was stated.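

In this assay the change from phenyl to 2,4-difluorophenyl on a saturated chain carbon bound to an aromatic nitrogen gives a 1.1-fold lower number from compound 1 to compound 3 (0.04 log units; within the scatter) and so leaves the two compounds indistinguishable. Among these compounds, this is the only measured pair that speaks to this position, and it shows that benzyl can become 2,4-difluorobenzyl without a shift beyond repeat-to-repeat variation in this read-out. Nothing in the data shown accounts for why the two compounds read alike.

As far as these compounds go, whether a single fluorine, a chlorine, a methoxy group or an amine on the phenyl ring would move the number stays open, as does the effect of a longer chain in place of the benzyl carbon. One pair also cannot show whether this change would read the same way on a different core.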